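The source may hold more compounds than are shown below. What is called first, only, known or untested is meant among the compounds shown, and "the series" means these compounds.

Compound 1 `COC(=O)c1scc(-c2ccc(NC(=O)c3cc(I)ccc3F)cc2)c1OC`: "not determined" (no result reported) in a functional assay on HeLa cells (Homo sapiens) for antiproliferative activity, read by MTT assay, with a stated time of 24 h; a lower number here means a stronger inhibitor, a higher number a weaker inhibitor.
Compound 2 `COC(=O)c1scc(-c2ccc(NC(=O)c3ccc(F)c(Cl)n3)cc2)c1OC`: 16200 nM.

Among the measured compounds, compound 2 stands alone with a number in this assay, and that number marks it as a weak inhibitor; compound 1 gives nothing to compare it with. Compound 3 `COC(=O)c1scc(-c2ccc(NC(=O)c3ccc(C(F)(F)F)cc3)cc2)c1OC` differs from compound 2 in one place: 4-(trifluoromethyl)phenyl in place of 6-chloro-5-fluoropyridin-2-yl on a carbonyl carbon. Within the data shown here, no step between two measured compounds exists to show what such a change does, so the expected step, a 1.2-fold lower number from compound 2 to compound 3 (0.06 log units; within the scatter), is small and lies within the usual scatter, in no firm direction. Compound 3 is accordingly expected to give 14000 nM, with a range from 4000 nM to 45000 nM.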

Compound 3, half-maximal inhibitory concentration: 14400 nM
For compound 3 the middle estimate is 1.0-fold (0.01 log units) below the measured one; measured number inside the range.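

In this assay, among these compounds, the change to 4-(trifluoromethyl)phenyl from 6-chloro-5-fluoropyridin-2-yl on a carbonyl carbon gives a 1.1-fold lower number from compound 2 to compound 3 (0.05 log units; within the scatter) and so provides the first measured step at this position. An aromatic ring of carbon only and one holding a ring nitrogen give readings that cannot be told apart here. No available measurement explains this result. Still open, as far as these compounds go, is whether a piperidine ring in place of these aromatic rings, or an amine or carboxylic acid on them, would shift the number beyond the scatter.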